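Carbamate series: benzyl carbamate step from compound 3

The source may hold more compounds than are shown below. What is called first, only, known or untested is meant among the compounds shown, and "the series" means these compounds.

Compound 3 `COC(=O)Nc1cccc(-c2ccc(N(C)C)cc2)c1` stands highest of the three numbers in hand: in an assay on COS-7 cells for inhibition of patatin-like phospholipase domain-containing protein 2 (Mus musculus), tested at 200 uM (a lower number here means less inhibition, a higher number more inhibition at the concentration tested (going by the name of the read-out)), compound 3 gives 95%. Compound 1 `CCOC(=O)c1cccc(-c2ccc(C(C)N(C)C)cc2)c1` gives 50% in this assay, and compound 2 `CN(C)c1ccc(-c2cccc([N+](=O)[O-])c2)cc1` gives 21%. For the measured compounds named here, the single one-point step among the measured compounds, a number 74 percentage points higher from compound 2 to compound 3 (beyond the scatter), runs from nitro to (methoxycarbonyl)amino and is large; it shows that the carbamate bearing the shared core carries the highest number here.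

Compound 4 `CN(C)c1ccc(-c2cccc(NC(=O)OCc3ccccc3)c2)cc1` differs from compound 3 by phenyl in place of hydrogen on a saturated chain carbon bound to an oxygen next to a carbonyl group, which cut one bond further out reads methyl to benzyl, methoxy to benzyloxy. Going by the values given here, no measured step concerns this kind of change; the one step known, from compound 2 to compound 3, exchanges the group on the aromatic carbon and does not speak to the ester-side extension. The carbamate itself stays in place, so compound 3 is the relevant anchor and its value 95% already lies near the top of the scale. Compound 4 is therefore expected to stay close to compound 3, with a step of a number 10 percentage points lower from compound 3 to compound 4 (within the scatter) that may well be within the scatter. The estimate for compound 4 in this assay is 85%, with a range from 60% to 100%.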

Compound 4, a percentage reported as inhibition, at one concentration (the size of the read-out at that concentration, not a potency): 50%
For compound 4 the middle estimate is 35 percentage points above the measured one; the whole stated range lies above it.
By their numbers in this assay, from the lowest: compound 2; then compounds 1 and 4 (each within the scatter of the next); then compound 3.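

In this assay the ester side of the carbamate proves sensitive: methoxy to benzyloxy, phenyl in place of hydrogen on a saturated chain carbon bound to an oxygen next to a carbonyl group, gives a large step, a number 45 percentage points lower from compound 3 to compound 4 (beyond the scatter). The carbamate stays in place across this step, so its presence alone does not secure the high number of compound 3, a point the nitro to (methoxycarbonyl)amino step could not show. Nothing in hand accounts for the drop.

Open, on these data alone, is whether the drop follows from the phenyl ring itself or from any extension beyond methyl: an ethyl group or a cyclohexylmethyl group in place of benzyl would separate the two. Also open, as far as these compounds go, is whether a urea, with an amine nitrogen in place of the ester oxygen, keeps the number of compound 3.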